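Cytotoxicity series: open-chain diamine replacing the bicyclic amine

This account rests on a few compounds, and the source may have more. Where it says the series, first, only, none or still open, it means among the compounds named here.

Of the compounds shown here, two have been measured in a functional assay on SV5A8 cells (Homo sapiens) for cytotoxicity; a lower number here means a stronger inhibitor, a higher number a weaker inhibitor. Compound 1 `Cc1ccc(CN2CCC(C(=O)Nc3ccc(CNc4nc(N(C)C)nc5cc(C)ccc45)cc3)CC2)cc1` gives only a limit of the assay, > 4150 nM. Compound 2 `Cc1ccc2c(NCc3ccc(NC(=O)C4CCN(Cc5ccccc5)CC4)cc3)nc(N3CCC(N4CCCC4)CC3)nc2c1` likewise gives only a limit, > 8090 nM. Where compound 2 stands is therefore known only as a limit, (the limit of > 8090 nM in this assay, at which 1 of the 2 values shown sits). The other value shown is also a limit, (the limit of > 4150 nM in this assay, at which 1 of the 2 values shown sits). Among the measured compounds shown here, no step between the two measured compounds is counted, as they differ in more than one place.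

Compound 3 `Cc1ccc2c(NCc3ccc(NC(=O)C4CCN(Cc5ccccc5)CC4)cc3)nc(N(C)CCN(C)C)nc2c1` is not yet measured. It differs from compound 2 in one place: (2-(dimethylamino)ethyl)(methyl)amino in place of 4-(pyrrolidin-1-yl)piperidin-1-yl on an aromatic carbon. With both measured values sitting at limits in this assay, no step beyond the scatter is expected from this change, and compound 3 is expected to remain at or near the limit. The step this estimate means, a number no higher from compound 2 to compound 3 (the limit leaves the size open), is expected to be none beyond the scatter. For compound 3 the estimate is 8000 nM, within 2500 nM to 25000 nM.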

Compound 3, half-maximal inhibitory concentration: > 8830 nM
Compound 3: only a limit was reported; the forecaster's own chance of this, stated with the estimate: 75%; middle value at least 1.1-fold (0.04 log units) from the limit.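

No new step can be read: compound 2 and compound 3 both stand only as limits of the assay, so their difference cannot be sized. Left open are the actual potencies of compound 1, compound 2 and compound 3, and whether replacing 4-(pyrrolidin-1-yl)piperidin-1-yl with (2-(dimethylamino)ethyl)(methyl)amino changes potency at all.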